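From a pyrimidinyl to a pyrrolyl group at one carbon

A few compounds are considered here, and "the series" means these few. Any claim that something is new, unique, unknown or untested is made for them only; others in the source may bear on it.

Compound 1 `Cc1ccnc(-c2ccccc2OCC2=NCCN2)c1`: < 100000 nM
Compound 2 `c1cnc(-c2ccccc2OCC2=NCCN2)nc1`: < 100000 nM

Both numbers come from a functional assay for activation of Alpha-1B adrenergic receptor (Homo sapiens), read by calcium flux; on this read-out lower numbers stand for an effect already at smaller amounts and higher numbers for an effect only at larger amounts of compound. For compound 1 the value < 100000 nM is a limit of the assay and not a number. For compound 2 the value < 100000 nM is likewise a limit of the assay. Compound 2 thus stands at the limit of < 100000 nM in this assay, at which 2 of the 2 values shown sit, with no real number to place it. Compound 3 `c1c[nH]c(-c2ccccc2OCC2=NCCN2)c1` arises from compound 2 by 1H-pyrrol-2-yl in place of pyrimidin-2-yl on an aromatic carbon. Going by the values given here, no step between measured compounds exists, so the direction of the change cannot be read from the data. The estimated step that the limit leaves unreadable from compound 2 to compound 3 is set at nothing beyond the usual scatter. Compound 3 is expected to give 5000 nM, between 500 nM and 50000 nM.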

Compound 3, half-maximal effective concentration: 1 nM
For compound 3 the middle estimate is 5000-fold (3.70 log units) above the measured one; measured number below the stated range.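

No step can be read between compound 3 and compound 2, whose < 100000 nM is a limit of the assay and not a number. The compounds shown leave open how large a change 1H-pyrrol-2-yl brings in place of pyrimidin-2-yl.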